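The source may report more compounds than this note shows. Statements on the series, on what has been measured and on what is new or still open speak of the compounds shown alone.

Measured compounds in a functional assay on PC-3 cells (Homo sapiens) for inhibition, read by MTT assay, with a stated time of 72 h; on this read-out higher numbers stand for weaker inhibition and lower numbers for stronger inhibition:

Compound 1, `C=CC(=O)Nc1cccc(NC(=O)CSc2nc(Nc3ccccc3)c3ccccc3n2)c1`: 8740 nM
Compound 2, `O=C(CSc1nc(Nc2ccccc2)c2ccccc2n1)Nc1ccc(C(F)(F)F)cc1`: 10400 nM
Compound 3, `O=C(CSc1nc(Nc2ccccc2)c2ccccc2n1)Nc1ccc(Cl)c(Cl)c1`: 12100 nM

Compound 1 gives the lowest of the three numbers, but its separation from the others is small: the step of a 1.2-fold higher number from compound 1 to compound 2 (0.08 log units; within the scatter) and the step of a 1.4-fold higher number from compound 1 to compound 3 (0.14 log units; within the scatter) both lie within the scatter, as does the step of a 1.2-fold higher number from compound 2 to compound 3 (0.07 log units; within the scatter). The three measured compounds are therefore indistinguishable on this read-out.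

Compound 4, `C=CC(=O)Nc1cccc(NC(=O)CSc2nc(Nc3ccc(Cl)c(Cl)c3)c3ccccc3n2)c1`, has not yet been measured. It differs from compound 1 by 3,4-dichlorophenyl in place of phenyl on a nitrogen on an aromatic ring. Among the measured compounds shown here, none of the measured steps touches this nitrogen; all three exchange the aryl group on the amide nitrogen. For the measured compounds named here, the nearest precedent is the entry of the same 3,4-dichlorophenyl group at that other place, the step of a 1.4-fold higher number from compound 1 to compound 3 (0.14 log units; within the scatter), which stayed within the scatter. The account therefore expects a step of a 1.1-fold higher number from compound 1 to compound 4 (0.04 log units; within the scatter), no larger than the scatter, in either direction. The estimate for compound 4 in this assay is 9500 nM, with a range of 3000 nM to 30000 nM.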

Compound 4, half-maximal inhibitory concentration: 27600 nM
Compound 4: the middle estimate sits 2.9-fold (0.46 log units) below what was measured; the range from low to high includes it.
By their numbers in this assay, from the lowest: compounds 1, 2 and 3 (each within the scatter of the next); then compound 4.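

In this assay, among the compounds shown here, the exchange of phenyl for 3,4-dichlorophenyl on a nitrogen on an aromatic ring gives a 3.2-fold higher number from compound 1 to compound 4 (0.50 log units; beyond the scatter), the only step so far that lies beyond the scatter, and it runs towards weaker inhibition. The same group entering on the amide-type nitrogen gave a 1.4-fold higher number from compound 1 to compound 3 (0.14 log units; within the scatter), so the two places do not answer alike to this exchange. Nothing shown here offers an explanation for this difference.

This place rests on a single modest step, so the compounds shown do not tell whether one chlorine alone, a methoxy group or a carboxylic acid on that phenyl would move the number in the same way. They also leave open whether the step holds when the amide nitrogen carries 4-(trifluoromethyl)phenyl instead of 3-((vinylcarbonyl)amino)phenyl.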